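The compounds below may be only part of what the source reports. "The series", "measured", "known", "first", "only" and "open" are said of these compounds alone.

Working notes on the series. Three compounds share one core and differ only in the group on a saturated chain carbon bound to an aromatic nitrogen. Compound 1 `Nc1nc(O)c2c(n1)n(C1OC(CO)[C@@H](O)[C@H]1O)c(=O)n2CC(O)CSc1ccccc1` gives 142 uM in a functional assay (B cells) with Mus musculus as the target; a lower number here means that less compound is needed, a higher number that more compound is needed for the effect. Compound 2 `CN(C)CCCn1c(=O)n(C2OC(CO)[C@@H](O)[C@H]2O)c2nc(N)nc(O)c21` gives 194 uM in this assay; the pair shows a 1.4-fold higher number from compound 1 to compound 2 (0.14 log units; within the scatter). Compound 3 `Nc1nc(O)c2c(n1)n(C1OC(CO)[C@@H](O)[C@H]1O)c(=O)n2Cc1ccc(Cl)cc1` gives 14 uM in this assay and stands at the lowest number of the three, with a 10-fold lower number from compound 1 to compound 3 (1.01 log units; beyond the scatter) and a 14-fold lower number from compound 2 to compound 3 (1.14 log units; beyond the scatter) both beyond the scatter.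

Compound 4 `Cn1c(=O)n(C2OC(CO)[C@@H](O)[C@H]2O)c2nc(N)nc(O)c21` is not yet measured. The change from compound 3 is hydrogen in place of 4-chlorophenyl on a saturated chain carbon bound to an aromatic nitrogen. For the measured compounds named here, the steps that bear on it are those into compound 3: the 4-chlorophenyl gave a large lowering of the number against both of the other groups on that carbon. Compound 4 carries nothing but hydrogen there, so the step is expected to run the other way, back toward the range of compound 1 and compound 2, and the estimate for compound 4 is 150 uM in this assay, within 50 uM to 450 uM. That estimate corresponds to an 11-fold higher number from compound 3 to compound 4 (1.03 log units; beyond the scatter), a step expected to lie beyond the scatter because of a 10-fold lower number from compound 1 to compound 3 (1.01 log units; beyond the scatter).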

Compound 4, concentration for half-maximal effect: 10 uM
For compound 4 the middle estimate is 15-fold (1.18 log units) above the measured one; measured number outside the range, below it.
By their numbers in this assay, from the lowest: compounds 4 and 3 (each within the scatter of the next); then compounds 1 and 2 (each within the scatter of the next).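

In this assay the 4-chlorophenyl group proves not to be required for a low number at this position: hydrogen in its place removes 7 heavy atoms and the aromatic ring, yet the result is a 1.4-fold lower number from compound 3 to compound 4 (0.15 log units; within the scatter) and the 4-chlorobenzyl and methyl groups cannot be told apart. The compounds that stand apart are now those with the two other groups, seen in a 14-fold lower number from compound 1 to compound 4 (1.15 log units; beyond the scatter) and in a 19-fold lower number from compound 2 to compound 4 (1.29 log units; beyond the scatter), so the earlier drop into compound 3 reflects the loss of the 1-hydroxy-2-(phenylsulfanyl)ethyl and 2-(dimethylamino)ethyl groups rather than anything shown to be gained with the 4-chlorophenyl. The data on hand offer no measurement that explains this split between the groups.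

Open, from the compounds shown here alone, is where the change sets in: an ethyl, a plain n-butyl or a chain ending in a carboxylic acid could fall with compound 3 and compound 4 or with compound 1 and compound 2. Also open, going by these compounds, is whether the hydroxyl, the phenylsulfanyl or the dimethylamino group alone is enough to raise the number, as each appears only in a single compound or in one combination.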